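The source may report more compounds than this note shows. Statements on the series, on what has been measured and on what is new or still open speak of the compounds shown alone.

Measured so far in a functional assay on ECa-109 cells (Homo sapiens) for cytotoxicity, read by MTT assay, with a stated time of 72 h; a higher number here means a weaker inhibitor, a lower number a stronger inhibitor:
compound 1 `Cc1cc(Nc2ccc(Cl)cc2)nc(SCc2nc3ccccc3[nH]2)n1`: 20400 nM
compound 2 `Cc1cc(N2CCNCC2)nc(SCc2nc3ccccc3[nH]2)n1`: > 100000 nM, a limit of the assay, not a number
compound 3 `Cc1cc(NNC(N)=S)nc(SCc2nc3ccccc3[nH]2)n1`: > 100000 nM, likewise a limit

Among the measured compounds shown here, compound 1 carries the only real number in this assay; the other two values sit at the limit (the limit of > 100000 nM in this assay, at which 2 of the 3 values shown sit). The steps of an at least 4.9-fold higher number from compound 1 to compound 2 (0.69 log units; beyond the scatter) and an at least 4.9-fold higher number from compound 1 to compound 3 (0.69 log units; beyond the scatter) both replace the whole (4-chlorophenyl)amino group and push the number beyond the scatter. Compound 4 `Cc1cc(Nc2ccc(F)cc2)nc(SCc2nc3ccccc3[nH]2)n1` keeps that group and differs from compound 1 only by fluoro in place of chloro on an aromatic carbon. For the measured compounds named here, no measured step touches a substituent on this ring, so the measured steps give no ground for a shift beyond the scatter; the expected step of a 1.2-fold higher number from compound 1 to compound 4 (0.09 log units; within the scatter) is within it. Compound 4 is therefore estimated at 25000 nM, with a range from 10000 nM to 60000 nM.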

Compound 4, half-maximal inhibitory concentration: 69500 nM
Estimate against measurement, compound 4: 2.8-fold (0.44 log units) below; measured number outside the range, above it.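

Notes on the series: the para substituent on the aryl amino group matters in this assay, since fluoro in place of chloro, with the rest of the structure unchanged, gives a 3.4-fold higher number from compound 1 to compound 4 (0.53 log units; beyond the scatter). Against the two limit values, the comparison yields only floors, an at least 1.4-fold lower number from compound 3 to compound 4 (0.15 log units; that floor lies within the scatter) and an at least 1.4-fold lower number from compound 2 to compound 4 (0.15 log units; that floor lies within the scatter), so these steps do not separate the fluoro compound from the piperazin-1-yl or thiosemicarbazide-type groups. Those two values are limits, not numbers: the limit of > 100000 nM in this assay, at which 2 of the 4 values shown sit.

As far as these compounds go, what bromo, methyl or methoxy at this place would give stays open.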